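This account rests on a few compounds, and the source may have more. Where it says the series, first, only, none or still open, it means among the compounds named here.

Of the compounds shown here, two have so far been tested in a functional assay on PC-3M cells (Homo sapiens) for cytotoxicity, read by MTT assay, with a stated time of 48 h; a lower number here means a stronger inhibitor, a higher number a weaker inhibitor. Compound 1, `CCc1nnc(SCC(=O)c2ccc(C)cc2)n1N1C(=O)c2ccccc2C1=O`, gives only a limit of the assay in this assay, with a reading of > 200000 nM. Compound 2, `C#CCSc1nnc(-c2cc(OC)c(OC)c(OC)c2)n1N1C(=O)c2ccccc2C1=O`, also gives only a limit in this assay, with a reading of > 200000 nM. Compound 2 therefore stands where every measured value stands: the limit of > 200000 nM in this assay, at which 2 of the 2 values shown sit, and there is no number within the range of the assay to place it against.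

The next compound, compound 3, `COc1ccc(C(=O)CSc2nnc(-c3cc(OC)c(OC)c(OC)c3)n2N2C(=O)c3ccccc3C2=O)cc1`, differs from compound 2 in a single place: (4-methoxyphenyl)carbonyl in place of ethynyl on a saturated chain carbon bound to a sulfur. Among the compounds with values here, no measured pair shows what such a change does in this assay. Compound 2 offers only a limit as a starting point. The step of a number no higher from compound 2 to compound 3 (the limit leaves the size open) is expected to be none beyond the scatter, in either direction. Compound 3 is accordingly expected to read 200000 nM, with a range from 50000 nM to 600000 nM, and the most likely outcome is that compound 3 again gives only a limit rather than a number.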

Compound 3, half-maximal inhibitory concentration: 32800 nM
The estimate for compound 3 lay 6.1-fold (0.79 log units) above the measured number, and the stated range ends above it.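

In this assay, within the data shown here, the two earlier compounds gave no number at all, and compound 3 is the first to give one, so this position on a saturated chain carbon bound to a sulfur can carry a change that brings the reading into the measurable range. Going by these compounds, putting (4-methoxyphenyl)carbonyl in place of ethynyl there gives an at least 6.0-fold lower number from compound 2 to compound 3 (0.78 log units; beyond the scatter) and the full size of that step stays open, since it starts from a limit rather than a number. Compound 2 gives only a limit of the assay, a standing it shares with compound 1: the limit of > 200000 nM in this assay, at which 2 of the 3 values shown sit 

On these data alone, this single change brings in a carbonyl, an aromatic ring and a methoxy group all at once, so it remains open which of these parts matters, and whether a plain phenylcarbonyl without the methoxy group, or a benzyl group without the carbonyl, would read the same. Also open, as far as these compounds go, is what an amine or a carboxylic acid on that aromatic ring would do to the reading in this assay and whether any such group would give a lower number than compound 3 does.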